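The source may hold more compounds than are shown below. What is called first, only, known or untested is meant among the compounds shown, and "the series" means these compounds.

Working notes on the series. In an ADME assay on HeLa cells (Homo sapiens) for cytotoxicity, with a stated time of 48 h (a higher number here means that more compound is tolerated, a lower number that less compound is tolerated), compound 1 `CCC(CC)O[C@@H]1C=C(C(=O)Nc2ccccc2)C[C@H](N)[C@H]1NC(C)=O` gives 375000 nM and compound 2 `CCC(CC)O[C@@H]1C=C(C(=O)O)C[C@H](NC(=O)OC(C)(C)C)[C@H]1NC(C)=O` gives 750000 nM, two values within the scatter of each other. Compound 3 `CCC(CC)O[C@@H]1C=C(C(=O)Nc2ccccc2)C[C@H](NC(=O)OC(C)(C)C)[C@H]1NC(C)=O` reads > 1000000 nM, which is a limit of the assay and not a number.

Compound 4 `CCC(CC)O[C@@H]1C=C(C(=O)Nc2ccccc2OC)C[C@H](N)[C@H]1NC(C)=O` departs from compound 1 at one place: methoxy in place of hydrogen on an aromatic carbon. This is methoxy in place of hydrogen on an aromatic carbon, ortho to a large group.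

Within the data shown here, no measured step changes a substituent on that aromatic ring, so the support is indirect. The step of an at least 1.3-fold higher number from compound 2 to compound 3 (0.12 log units; that floor lies within the scatter) brings in the anilino group itself, and its floor lies within the scatter. The step of an at least 2.6-fold higher number from compound 1 to compound 3 (0.42 log units; beyond the scatter) is beyond the scatter, but it places tert-butoxycarbonyl on the amine nitrogen, and compound 4 keeps the hydrogen there. Nothing measured therefore points to a large move in this assay, and compound 4 is expected to remain close to compound 1 at 375000 nM, with no step beyond the scatter in either direction.

The expected step, a 1.1-fold higher number from compound 1 to compound 4 (0.03 log units; within the scatter), lies within the scatter. For compound 4 the estimated value is 400000 nM, with an expected range from 170000 nM to 900000 nM.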

Compound 4, half-maximal cytotoxic concentration: 150000 nM
Compound 4: middle estimate off by 2.7-fold (0.43 log units), on the high side, and the stated range ends above it.
By their numbers in this assay, from the lowest: compound 4; then compounds 1 and 2 (each within the scatter of the next). At a limit, above all of these: compound 3.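

In this assay, the change from phenyl to 2-methoxyphenyl gives a 2.5-fold lower number from compound 1 to compound 4 (0.40 log units; beyond the scatter), which shows that a substituent on this aromatic ring, ortho to a large group, can move the number beyond the scatter. Among these compounds, no earlier step touched this ring, and the direction here is opposite to that of an at least 2.6-fold higher number from compound 1 to compound 3 (0.42 log units; beyond the scatter), a step at the amine nitrogen and not at this position. Compound 4 gives a number and not a limit, so its step can be read in full, whereas compound 3 alone stands at a limit: the limit of > 1000000 nM in this assay, at which 1 of the 4 values shown sits.

Whether this step belongs to methoxy itself or would follow any group at this place stays open, as a chloro or methyl group here, or methoxy on another carbon of the ring, is not among the compounds shown. Also open, from the compounds shown here alone, is whether the same ring change would carry over with tert-butoxycarbonyl on the amine nitrogen or with a free carboxylic acid in place of the anilino group, and these compounds give no cause for the step.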